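The compounds below may be only part of what the source reports. "The series", "measured", "known", "first", "only" and "open" are said of these compounds alone.

Measured so far in an ADME assay on MT4 cells (Homo sapiens) for cytotoxicity, read by MTT assay, with a stated time of 5 days; on this read-out higher numbers stand for lower toxicity in this test and lower numbers for higher toxicity in this test:
compound 1 `Cc1cc(C)c(Oc2cc(Nc3ccc(C#N)cc3)ncc2C(=O)NCc2cn(Cc3ccccc3C#N)nn2)c(C)c1` gives > 219000 nM, a limit of the assay.
compound 2 `CC(=O)Cn1cc(CNC(=O)c2cnc(Nc3ccc(C#N)cc3)cc2Oc2c(C)cc(C)cc2C)nn1` gives 19400 nM.
compound 3 `Cc1cc(C)c(Oc2cc(Nc3ccc(C#N)cc3)ncc2C(=O)NCc2cn(Cc3cccc(C#N)c3)nn2)c(C)c1` gives >= 129000 nM, a limit of the assay.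

Compound 3 therefore stands at a limit of this assay, not at a number; compound 1 also sits at a limit (the limit of > 219000 nM in this assay, at which 1 of the 3 values shown sits), and compound 3 at its own (the limit of >= 129000 nM in this assay, at which 1 of the 3 values shown sits). The step that the two limits leave unreadable from compound 1 to compound 3 is consequently unreadable. Only compound 2, with acetyl on the saturated chain carbon bound to the aromatic nitrogen, returns a number, and the steps of an at least 11-fold lower number from compound 1 to compound 2 (1.05 log units; beyond the scatter) and an at least 6.6-fold higher number from compound 2 to compound 3 (0.82 log units; beyond the scatter) show the two aryl groups give the higher, less toxic readings.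

Compound 4 `Cc1cc(C)c(Oc2cc(Nc3ccc(C#N)cc3)ncc2C(=O)NCc2cn(Cc3ccc(Cl)cc3)nn2)c(C)c1` changes compound 3 by 4-chlorophenyl in place of 3-cyanophenyl on a saturated chain carbon bound to an aromatic nitrogen. For the measured compounds named here, no measured step compares two such aryl groups readably; the only aryl-to-aryl step is the unreadable one from compound 1 to compound 3, while the readable steps concern acetyl against aryl. With both aryl analogues at limits, the step that the limit leaves unreadable from compound 3 to compound 4 is expected to stay within the scatter. For compound 4 the estimate in this assay is 150000 nM, with a range from 40000 nM to 400000 nM, most likely reported again as a limit.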

Compound 4, half-maximal cytotoxic concentration: >= 120000 nM
Compound 4: no number, only a limit; the forecaster's own chance of this, stated with the estimate: 65%; the middle value lies beyond the limit too.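

In this assay compound 4, with 4-chlorobenzyl in place of 3-cyanobenzyl, again gives no number but a limit: the limit of >= 120000 nM in this assay, at which 1 of the 4 values shown sits.

For the compounds shown here, the one readable step, an at least 6.1-fold higher number from compound 2 to compound 4 (0.79 log units; beyond the scatter), puts 4-chlorophenyl on the same side of acetyl as the two cyanophenyl groups of compounds 1 and 3, so at this position the higher reading also occurs with an aryl group carrying no nitrile. The steps among compounds 1, 3 and 4 all join limits and cannot be read, which leaves the three aryl groups unordered.

As far as these compounds go, whether the lower reading of compound 2 belongs to the acetyl itself or to the lack of an aryl group stays open. Also open, from the compounds shown here alone, is how an amine, a carboxylic acid or a plain longer alkyl chain on the saturated chain carbon bound to the aromatic nitrogen would read in this assay.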